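The source may report more compounds than this note shows. Statements on the series, on what has been measured and on what is new or still open speak of the compounds shown alone.

Values in an ADME assay on MT4 cells (Homo sapiens) for cytotoxicity, read by MTT assay, with a stated time of 4 days; a lower number here means that less compound is tolerated, a higher number that more compound is tolerated:
- compound 1 `CC(=O)Nc1ccc2oc(-c3ccccc3)c(O)c(=O)c2c1`: 64700 nM
- compound 2 `CC(=O)Nc1ccc2oc(-c3cccc(F)c3)c(O)c(=O)c2c1`: 26500 nM

Compound 2 holds the lower of the two numbers in this assay, at 26500 nM, so less of it is tolerated than of compound 1. The next compound, compound 3 `CC(=O)Nc1ccc2oc(-c3ccc(F)cc3)c(O)c(=O)c2c1`, is an isomer of compound 2 with 4-fluorophenyl in place of 3-fluorophenyl on an aromatic carbon.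

Among the measured compounds shown here, only one measured step bears on this change: a 2.4-fold lower number from compound 1 to compound 2 (0.39 log units; beyond the scatter). That modest step came with fluoro in place of hydrogen on an aromatic carbon. For the measured compounds named here, no measured compound carries 4-fluorophenyl, so there is no direct precedent for this group. Compound 3 keeps the same atoms as compound 2, so a step smaller than the one measured is expected in this assay, most likely none beyond the scatter. Any lean would be slightly upward, toward compound 1 at 64700 nM, but this is weakly supported.

The estimate for compound 3 is 32000 nM, with an expected range of 14000 nM to 70000 nM. This estimate means a 1.2-fold higher number from compound 2 to compound 3 (0.08 log units; within the scatter).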

Compound 3, half-maximal cytotoxic concentration: 34100 nM
Estimate against measurement, compound 3: 1.1-fold (0.03 log units) below; the range from low to high includes it.
By their numbers in this assay, from the lowest: compounds 2, 3 and 1 (each within the scatter of the next, the first and the last beyond it).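

In this assay, 4-fluorophenyl in place of 3-fluorophenyl gives a 1.3-fold higher number from compound 2 to compound 3 (0.11 log units; within the scatter) and so does not separate the two fluoro isomers at this aromatic carbon of the shared core. Fluoro in place of hydrogen on the phenyl ring gives a 1.9-fold lower number from compound 1 to compound 3 (0.28 log units; within the scatter) when it forms 4-fluorophenyl, whereas the earlier step to 3-fluorophenyl was a 2.4-fold lower number from compound 1 to compound 2 (0.39 log units; beyond the scatter) and so lay beyond the scatter; only compound 2 therefore stands clearly apart from compound 1, and compound 3 lies within the scatter of both. No supporting data bear on the reason for this pattern.

Three compounds with one kind of substituent leave open whether the small spread at this position holds for a chloro, methoxy, or carboxylic acid group on the phenyl ring, or for a larger group such as a benzyl in place of the phenyl. They also leave open how the tolerated concentration responds to changes elsewhere on the core, such as a free amine in place of the amide.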